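Dithiocarbamate chromone series: amine swap at the thiocarbonyl

A few compounds are considered here, and "the series" means these few. Any claim that something is new, unique, unknown or untested is made for them only; others in the source may bear on it.

Working notes on a small series built on the core of compound 1 `CCOC(=O)c1cc(=O)c2cc(CSC(=S)N(C(C)C)C(C)C)ccc2o1`. In a functional assay on MCF7 cells (Homo sapiens) for antiproliferative activity, read by MTT assay, with a stated time of 72 h (on this read-out lower numbers stand for stronger inhibition and higher numbers for weaker inhibition), compound 1 gives only a limit of the assay, > 25000 nM. Compound 2 `O=c1cc(CSC(=S)N2CCCC2)oc2cc(Cl)ccc12` likewise returns only a limit, > 25000 nM. Among the compounds with values here, compound 3 `COc1ccc2oc(CSC(=S)N3CCCCC3)cc(=O)c2c1` is the one member with a numerical reading, 10000 nM. Compound 1 therefore stands at the edge of what this assay reports, a position shared with compound 2 and summarised by the limit of > 25000 nM in this assay, at which 2 of the 3 values shown sit. Within the data shown here, no two measured compounds differ in a single place, so no measured step is available to calibrate the change below.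

Compound 4 `CCOC(=O)c1cc(=O)c2cc(CSC(=S)N3CCOCC3)ccc2o1` differs from compound 1 in one place: morpholin-4-yl in place of diisopropylamino on a thiocarbonyl carbon. Among the measured compounds shown here, with no measured step to lean on, and compound 1 already reaching the limit > 25000 nM, the expected step is a step that the limit leaves unreadable from compound 1 to compound 4, none beyond the scatter. Compound 4 is estimated at 30000 nM, within a range from 8000 nM to 100000 nM, and this assay is expected more often than not to report only a limit for it.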

Compound 4, half-maximal inhibitory concentration: > 25000 nM
Compound 4 was reported as a limit (the forecaster's own chance of this, stated with the estimate: 60%); the middle value is on the limit's open side.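

Compound 1 and compound 4 both stand only as limits in this assay, so morpholin-4-yl in place of diisopropylamino gives no readable step: the limit of > 25000 nM in this assay, at which 3 of the 4 values shown sit.

The compounds shown leave open whether any amine on the thiocarbonyl carbon of this core gives a numerical reading in this assay.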